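This account rests on a few compounds, and the source may have more. Where it says the series, first, only, none or still open, it means among the compounds named here.

Measured compounds, with their values in a functional assay for inhibition, with Homo sapiens as the target; on this read-out higher numbers stand for weaker inhibition and lower numbers for stronger inhibition:
compound 1 `CCOC(=O)C(=O)N(c1ccccc1)c1nccc(-c2ccncc2)n1` gives 2200 nM
compound 2 `c1cc(Nc2nccc(-c3ccco3)n2)cc(-n2ccnc2)c1` gives 800 nM
compound 3 `CCc1ccc(Nc2nccc(-c3cnccn3)n2)cc1` gives 1900 nM

Compound 2 stands lowest of the three numbers in this assay, and so is the most potent here: compound 3 is the nearest and compound 1 the furthest, both beyond the usual scatter.

Compound 4 `c1cc(Nc2nccc(-c3ccco3)n2)cc(OCCn2ccnc2)c1` is not yet measured. It differs from compound 2 in one place: 2-(1H-imidazol-1-yl)ethoxy in place of 1H-imidazol-1-yl on an aromatic carbon. The group that enters keeps the same ring and adds a short linker with one more hydrogen-bond acceptor.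

Among the measured compounds shown here, no measured pair shows the effect of such a change, so the direction is open. The expectation for compound 4 is a step of a 1.3-fold higher number from compound 2 to compound 4 (0.10 log units; within the scatter) within the scatter, in either direction. Compound 4 is thus estimated at 1000 nM, within 300 nM to 3500 nM.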

Compound 4, half-maximal inhibitory concentration: 200 nM
Compound 4: the middle estimate sits 5.0-fold (0.70 log units) above what was measured; the whole stated range lies above it.
By their numbers in this assay, from the lowest: compound 4; then compound 2; then compounds 3 and 1 (each within the scatter of the next).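

In this assay the swap of 1H-imidazol-1-yl for 2-(1H-imidazol-1-yl)ethoxy gives a 4.0-fold lower number from compound 2 to compound 4 (0.60 log units; beyond the scatter) and so lies beyond the scatter. This aromatic carbon, meta to a large group, therefore accepts the larger group, and the same ring on a linker gives a lower number here. Nothing at hand bears on the cause of this step. Still open, from the compounds shown here alone, is whether the step follows the ether oxygen or the added length. Also open, going by these compounds, is whether a longer chain, or an amine in place of the imidazole ring, would keep it.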